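Acetyl to Propanoyl Carried Over to a Second Core

A few compounds are considered here, and "the series" means these few. Any claim that something is new, unique, unknown or untested is made for them only; others in the source may bear on it.

The series opens with compound 1 `CC(=O)N1CCCN(S(=O)(=O)c2ccc(F)cc2)CC1`, which in a functional assay on the whole organism with Mus musculus as the target (on this read-out higher numbers stand for an effect only at larger amounts of compound and lower numbers for an effect already at smaller amounts), gives 1 mg/kg. Its companion compound 2 `CCC(=O)N1CCCN(S(=O)(=O)c2ccc(F)cc2)CC1` carries one extra carbon in the amide, and in this assay compound 2 gives 1 mg/kg. The step of no change at the digits printed from compound 1 to compound 2 (within the scatter) is therefore flat, and the change behind it is methyl in place of hydrogen on a saturated chain carbon bound to a carbonyl carbon.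

Compound 3 `CCCS(=O)(=O)N1CCN(C(C)=O)C1` rests on a different core; how that core differs from the core of compound 1 is not broken down here. In this assay compound 3 gives 10 mg/kg, the highest number of the three measured compounds, and its distance from both compound 1 and compound 2 lies beyond the usual scatter.

Compound 4 `CCCS(=O)(=O)N1CCN(C(=O)CC)C1` is still to be measured. It is related to compound 3 through (methyl in place of hydrogen on a saturated chain carbon bound to a carbonyl carbon), which is the same change that links compound 1 to compound 2, and the place of the change is described in identical words for both pairs.

Because no change at the digits printed from compound 1 to compound 2 (within the scatter) showed no movement when the same change was made on the first core, the expectation for compound 4 is that the step of no change at the digits printed from compound 3 to compound 4 (within the scatter) will also stay within the scatter. Compound 4 is accordingly estimated to give 10 mg/kg in this assay, with the likely range running from 3 mg/kg to 30 mg/kg. This expectation rests on a single measured pair and on one unmeasured compound, so it remains a tentative one.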

Compound 4, minimum effective dose: > 10 mg/kg
Compound 4: no number, only a limit; the forecaster's own chance of this, stated with the estimate: 10%; the middle value sits exactly at the limit.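

Compound 4 gives > 10 mg/kg in this assay, which is a limit of the assay and not a number. On the core of compound 3, the swap of acetyl for propanoyl therefore gives a number no lower from compound 3 to compound 4 (the limit leaves the size open), so the result shows only that the number did not come out lower on this core; it neither confirms that the flat step seen on the first core carries over nor shows that the two cores part ways: the same change on two cores in this assay, no change at the digits printed (within the scatter) from compound 1 to compound 2 and a number no lower (the limit leaves the size open) from compound 3 to compound 4; the limit leaves it open whether they differ The comparison also rests on a single pair for each core, and its second half is bounded by what the read-out reports: the limit of > 10 mg/kg in this assay, at which 1 of the 4 values shown sits.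

The compounds shown leave open how far compound 4 actually lies from compound 3, and so whether methyl in place of hydrogen at this place behaves alike on the two cores. They also leave open how a longer chain on the carbonyl, such as butanoyl, or an amine or a carboxylic acid carried on that chain, would read on either core in this assay.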